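This account rests on a few compounds, and the source may have more. Where it says the series, first, only, none or still open, it means among the compounds named here.

The account follows one change within a small set of compounds tested in a toxicity assay on NIH3T3 cells (Mus musculus) for cytotoxicity, read by resazurin assay; on this read-out lower numbers stand for an effect already at smaller amounts and higher numbers for an effect only at larger amounts of compound. Compound 1 `CC(C)c1ccc(Cn2cncc2CNc2ccc(-c3nc4ccccc4s3)c(-c3ccccc3)c2)cc1` reaches in this assay only the limit of the assay, > 1000 nM. Compound 3 `Cc1ccccc1-c1ccc(Cn2cncc2CNc2ccc(-c3nc4ccccc4s3)c(-c3ccccc3)c2)cc1` likewise gives in this assay only the limit > 1000 nM, so compound 3 stands at the assay limit and not at a number. The step that the two limits leave unreadable from compound 1 to compound 3 is therefore unreadable, and this is fixed by the limit of > 1000 nM in this assay, at which 2 of the 3 values shown sit. Compound 2 `Clc1ccc(Cn2cncc2CNc2cccc(-c3ccccc3)c2)cc1`, a smaller compound that also carries a chloro group, gives in this assay a number, 10000 nM.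

Compound 4 `Clc1ccc(Cn2cncc2CNc2ccc(-c3nc4ccccc4s3)c(-c3ccccc3)c2)cc1` differs from compound 3 by chloro in place of 2-methylphenyl on an aromatic carbon. Within the data shown here, no measured step covers this change, and the single measured step is the unreadable one already named. Compound 4 is therefore expected to remain a compound with an effect only at larger amounts, and its estimated step that the limit leaves unreadable from compound 3 to compound 4 cannot be resolved against a limit. The estimate for compound 4 is 5000 nM, with a range from 1500 nM to 20000 nM, and the assay may well again report only its limit for compound 4.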

Compound 4, half-maximal effective concentration: > 1000 nM
Compound 4 ended at the assay's limit; the forecaster's own chance of this, stated with the estimate: 60%; the middle value does not contradict the limit.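

No step from compound 1, compound 2 or compound 3 to compound 4 can be read, because compound 4 gives a limit and not a number: the limit of > 1000 nM in this assay, at which 3 of the 4 values shown sit.

The compounds shown leave open where compound 1, compound 3 and compound 4 actually lie, and so whether isopropyl, 2-methylphenyl and chloro differ at all.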